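Phenyl on the sulfur ring of compound 1

This account rests on a few compounds, and the source may have more. Where it says the series, first, only, none or still open, it means among the compounds named here.

In a functional assay on BMEC cells (Bos taurus) for antiproliferative activity (a lower number here means a stronger inhibitor, a higher number a weaker inhibitor), compound 1 `COc1cc(/C=C\Cc2cc(O)c3ccsc3c2)cc(OC)c1OC` gives 87 nM, the second highest of the three numbers. Compound 2 `COc1cc(/C=C/Cc2cc(O)c3ccsc3c2)cc(OC)c1OC` gives 38700 nM, a 440-fold higher number from compound 1 to compound 2 (2.65 log units; beyond the scatter). That large step rests on (the fact that compounds 1 and 2 differ only in the configuration as drawn). Compound 4 `COc1cc(/C=C\Cc2cc(O)c3c(-c4ccccc4)csc3c2)cc(OC)c1OC` keeps the double bond drawn Z, as in compound 1, so this step says little about it. Compound 3 `COc1cc(/C=C\Cc2cc(O)c3cc(C)sc3c2)cc(OC)c1OC` gives 23 nM, a 3.8-fold lower number from compound 1 to compound 3 (0.58 log units; beyond the scatter).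

The change under study is phenyl in place of hydrogen on an aromatic carbon. Going by the values given here, the only measured substitution step is the modest one to compound 3, and it introduces a methyl, not a phenyl. It is therefore a weak guide, and its direction is not carried over with confidence. A modest move towards a higher number is expected in this assay, with a wide margin that includes no change or a small gain. The expected step is a 2.9-fold higher number from compound 1 to compound 4 (0.46 log units; beyond the scatter). For compound 4 the estimated value is 250 nM, with an expected range of 30 nM to 2500 nM.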

Compound 4, half-maximal inhibitory concentration: > 2000 nM
Compound 4 ended at the assay's limit; the forecaster's own chance of this, stated with the estimate: 8%; middle value at least 8.0-fold (0.90 log units) away from the limit.
By their numbers in this assay, from the lowest: compound 3; then compound 1; then compound 2.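

In this assay compound 4 gives > 2000 nM, a limit of the assay and not a number: the limit of > 2000 nM in this assay, at which 1 of the 4 values shown sits. Going by these compounds alone, this is the first reading of the aromatic carbon two ring bonds from the ring sulfur, as no earlier compound carries a substituent there. With the double bond still drawn Z, phenyl in place of hydrogen gives an at least 22-fold higher number from compound 1 to compound 4 (1.36 log units; beyond the scatter), so this position does not accept every substituent, and a large loss can arise without any change in the double bond.

Going by these compounds, how far the true number of compound 4 lies past the limit stays open. Also open, on these data alone, is which feature of phenyl matters, and whether ethyl or an amine on this same carbon would keep the number near that of compound 1.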